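The compounds below may be only part of what the source reports. "The series", "measured", "known", "first", "only" and "open" are said of these compounds alone.

Measured compounds in a functional assay on DU-145 cells (Homo sapiens) for cytotoxicity, read by MTT assay, with a stated time of 48 h; on this read-out higher numbers stand for weaker inhibition and lower numbers for stronger inhibition:
compound 1 `CCOC(=O)c1c(-c2cc3ccccc3oc2=O)nn(-c2cccc(Cl)c2)c1C(=O)OCC` gives 35000 nM;
compound 2 `CCOC(=O)c1c(-c2cc3ccc(OC)cc3oc2=O)nn(-c2cccc(Cl)c2)c1C(=O)OCC` gives 38000 nM;
compound 3 `CCOC(=O)c1c(-c2cc3ccc(OCC=C(C)C)cc3oc2=O)nn(-c2cccc(C)c2)c1C(=O)OCC` gives 125000 nM.

Compound 3 stands highest of the three numbers; compound 2 is nearest and compound 1 furthest, both gaps lying beyond the scatter.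

Compound 4 `CCOC(=O)c1c(-c2cc3ccc(OCC=C(C)C)cc3oc2=O)nn(-c2cccc(Cl)c2)c1C(=O)OCC` differs from compound 3 by chloro in place of methyl on an aromatic carbon.

Among the measured compounds shown here, the only single-point step measured, a 1.1-fold higher number from compound 1 to compound 2 (0.04 log units; within the scatter), concerns a different change and falls within the scatter, so no measured step isolates the exchange of methyl for chloro. Compounds 1 and 2, which both carry the 3-chlorophenyl, sit at lower numbers than compound 3, but they also differ from compound 3 in their second substituent, so the two changes cannot be separated on these data.

Expectation for compound 4 is therefore tentative: a modest lowering relative to compound 3, a 1.8-fold lower number from compound 3 to compound 4 (0.25 log units; within the scatter), with wide uncertainty in either direction. The estimated value for compound 4 is 70000 nM, range 25000 nM to 200000 nM.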

Compound 4, half-maximal inhibitory concentration: 139000 nM
Estimate against measurement, compound 4: 2.0-fold (0.30 log units) below; the range from low to high includes it.
By their numbers in this assay, from the lowest: compounds 1 and 2 (each within the scatter of the next); then compounds 3 and 4 (each within the scatter of the next).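

In this assay the change from 3-methylphenyl to 3-chlorophenyl gives a 1.1-fold higher number from compound 3 to compound 4 (0.05 log units; within the scatter) so this position does not separate chloro from methyl when the (3-methylbut-2-en-1-yl)oxy group is present. With the 3-chlorophenyl held constant, the other place does register: bringing in the (3-methylbut-2-en-1-yl)oxy group where only hydrogen stood gives a 4.0-fold higher number from compound 1 to compound 4 (0.60 log units; beyond the scatter) and 2-methylprop-1-en-1-yl in place of hydrogen on a saturated chain carbon bound to an oxygen on an aromatic ring gives a 3.7-fold higher number from compound 2 to compound 4 (0.56 log units; beyond the scatter) as a modest step in the same direction. No evidence to hand accounts for any of these steps.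

From the compounds shown here alone, whether chloro and methyl also match when hydrogen or methoxy takes the place of the (3-methylbut-2-en-1-yl)oxy group remains open. Also open, going by these compounds, is how an amine or a carboxylic acid on this phenyl ring would read.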